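This account rests on a few compounds, and the source may have more. Where it says the series, first, only, none or still open, it means among the compounds named here.

Compound 1: `CS(=O)(=O)c1ccc(Nc2ncc(F)c(Nc3nc4ccccc4s3)n2)cc1` gives 6880 nM
Compound 2: `CS(=O)(=O)c1ccc(Nc2nccc(Nc3nc4ccccc4s3)n2)cc1` gives 10600 nM
Compound 3: `NS(=O)(=O)c1ccc(Nc2nccc(Nc3nc4ccccc4s3)n2)cc1` gives 15300 nM

These three values come from a functional assay on MCF7 cells (Homo sapiens) for antiproliferative activity, read by MTT assay, with a stated time of 48 h; a higher number here means a weaker inhibitor, a lower number a stronger inhibitor. Among them compound 2 holds the second highest number. Its nearest neighbour is compound 3, reached by a 1.4-fold higher number from compound 2 to compound 3 (0.16 log units; within the scatter), a step that stays within the scatter. The other measured step, a 1.5-fold higher number from compound 1 to compound 2 (0.19 log units; within the scatter), also stays within the scatter. Taken together, the three numbers are close to one another and give no sign of a real difference.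

Compound 4 is `COc1ccc2nc(Nc3ccnc(Nc4ccc(S(C)(=O)=O)cc4)n3)sc2c1`. It differs from compound 2 in one place: methoxy in place of hydrogen on an aromatic carbon. Neither measured step touches this place. The step between compound 1 and compound 2 concerns fluoro against hydrogen on the central ring, and the step between compound 2 and compound 3 concerns amino against methyl on the sulfonyl sulfur. Both were small, and both sit elsewhere in the shared core, so they say little about a methoxy group on the fused ring. Among the compounds with values here, with no step that bears on this change, the expectation for this assay is no shift beyond the scatter in either direction, and the estimated step of no change at the digits printed from compound 2 to compound 4 (within the scatter) reflects that. For compound 4 the expected value is 10600 nM, with a range from 4000 nM to 28000 nM.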

Compound 4, half-maximal inhibitory concentration: > 50000 nM
Compound 4: a limit, no number; the forecaster's own chance of this, stated with the estimate: 5%; middle value at least 4.7-fold (0.67 log units) away from the limit.
By their numbers in this assay, from the lowest: compounds 1, 2 and 3 (each within the scatter of the next, the first and the last beyond it). At a limit, above all of these: compound 4.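

Within the data shown here, replacing hydrogen with methoxy on the six-membered aromatic ring of carbon only gives an at least 4.7-fold higher number from compound 2 to compound 4 (0.67 log units; beyond the scatter), the first step in this set to go beyond the scatter. In this assay compound 4 gives > 50000 nM, which is a limit of the assay and not a number, and it is the only compound shown at that limit: the limit of > 50000 nM in this assay, at which 1 of the 4 values shown sits. The earlier steps shown here, at other places in the shared core, gave no hint of this, so the new result marks this carbon as a place where a change can weaken the compound clearly, although it gives only a lower bound on the size of that effect.

The compounds shown leave open whether this weakening belongs to methoxy itself or would also appear with another group on the same carbon, such as methyl, chloro or hydroxyl. Among these compounds, they also leave open whether methoxy on a different carbon of the same ring would give a similar result, since this single change is the only evidence from that ring.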